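A Hydroxyphenyl Group Replaces the Methylfuranyl Substituent

A few compounds are considered here, and "the series" means these few. Any claim that something is new, unique, unknown or untested is made for them only; others in the source may bear on it.

Compound 1 `COc1cc(N2C(N)=C(C#N)C(c3ccc([N+](=O)[O-])cc3)C3=C2CC(C)(C)CC3=O)cc(OC)c1OC` gives 10%
Compound 2 `COc1cc(N2C(N)=C(C#N)C(/C=C/c3ccccc3)C3=C2CC(C)(C)CC3=O)cc(OC)c1OC` gives 10%
Compound 3 `COc1cc(N2C(N)=C(C#N)C(c3ccc(C)o3)C3=C2CC(C)(C)CC3=O)cc(OC)c1OC` gives 21%

The three measured compounds share one core and differ only in the group on a saturated ring carbon. In a functional assay on Ehrlich cells (Mus musculus) for cytotoxicity, tested at 10 ug/mL (on this read-out lower numbers stand for a weaker effect and higher numbers for a stronger effect at the one concentration tested), compound 3 stands highest of the three numbers: a number 11 percentage points higher from compound 1 to compound 3 (beyond the scatter) and a number 11 percentage points higher from compound 2 to compound 3 (beyond the scatter), both modest steps, whereas no change at the digits printed from compound 1 to compound 2 (within the scatter). Compound 3 is thus separated from the two others by more than the scatter, while compound 1 and compound 2 cannot be told apart on these numbers.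

Compound 4 `COc1cc(N2C(N)=C(C#N)C(c3ccc(O)cc3)C3=C2CC(C)(C)CC3=O)cc(OC)c1OC` differs from compound 3 by 4-hydroxyphenyl in place of 5-methylfuran-2-yl on a saturated ring carbon. For the measured compounds named here, the steps that bear on this change are those in which the 5-methylfuran-2-yl group is exchanged against another aromatic substituent, namely a number 11 percentage points higher from compound 1 to compound 3 (beyond the scatter) and a number 11 percentage points higher from compound 2 to compound 3 (beyond the scatter); run in the opposite direction, both point downward by a modest amount. Compound 1, which also carries a six-membered aromatic ring of carbon only on the same saturated ring carbon, gives 10% in this assay. Compound 4 is therefore expected to fall back toward that level, with an expected step of a number 9 percentage points lower from compound 3 to compound 4 (within the scatter). The estimate for compound 4 in this assay is 12%, with a range from 3% to 24%.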

Compound 4, a percentage reported as activity, at one concentration (the size of the read-out at that concentration, not a potency): 10%
Estimate against measurement, compound 4: 2 percentage points above; the range from low to high includes it.
By their numbers in this assay, from the lowest: compounds 1, 2 and 4 (each within the scatter of the next); then compound 3.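

With 4-hydroxyphenyl in place of 5-methylfuran-2-yl on the saturated ring carbon, this assay shows a number 11 percentage points lower from compound 3 to compound 4 (beyond the scatter), so compound 3 now stands apart from three different groups at this position rather than two. The result also adds a direct exchange on the six-membered aromatic ring of carbon only: hydroxy in place of nitro gives no change at the digits printed from compound 1 to compound 4 (within the scatter), and 4-hydroxyphenyl in place of 2-phenylethenyl gives no change at the digits printed from compound 2 to compound 4 (within the scatter), so compounds 1, 2 and 4 cannot be told apart on these numbers. Nothing available explains the separation of compound 3 from the other three compounds.

The compounds shown leave open whether the higher number of compound 3 goes with the five-membered aromatic ring, with its methyl group, or with both, and a furan-2-yl group without the methyl or a 5-methylthiophen-2-yl group would help to separate these readings. On these data alone, it also remains open whether an amino or carboxylic acid group on the phenyl ring would move the number away from that of compound 4.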